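Series notes: amine change on the shared core

The source may hold more compounds than are shown below. What is called first, only, known or untested is meant among the compounds shown, and "the series" means these compounds.

Within the data shown here, compound 1 `CCCN(CCC)c1nc(C)nc2c(-c3ccc(OC)nc3C)c(C)nn12` stands lowest of the two numbers so far in an assay on cell membranes for displacement of a labelled ligand from corticotropin-releasing factor receptor 1 (Rattus norvegicus); on this read-out lower numbers stand for stronger inhibition and higher numbers for weaker inhibition: compound 1 gives 5.7 nM. Among the measured compounds shown here, the only other measured member, compound 2 `CCN(CC)c1nc(C)nc2c(-c3c(C)cc(N(C)C)nc3C)c(C)nn12`, gives 58 nM in this assay; no single-point step joins the two, so their values are taken only as they stand, with compound 2 the higher number by a margin beyond the scatter.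

The next entry, compound 3 `CCC[C@H](C)Nc1nc(C)nc2c(-c3ccc(OC)nc3C)c(C)nn12`, keeps the core and the aromatic substituent of compound 1 and changes only the amine on the aromatic carbon: (1-methylbutyl)amino in place of dipropylamino on an aromatic carbon. For the measured compounds named here, no measured pair shows this kind of change, so nothing in the data sets its size. The expectation is a small step, most likely toward a somewhat higher number, possibly none beyond the scatter; compound 3 is expected to land at a 1.8-fold higher number from compound 1 to compound 3 (0.24 log units; within the scatter). Compound 3 is therefore estimated at 10 nM in this assay, with a range from 3 nM to 40 nM.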

Compound 3, half-maximal inhibitory concentration: 4.5 nM
For compound 3 the middle estimate is 2.2-fold (0.35 log units) above the measured one; the measured number falls inside the stated range.
By their numbers in this assay, from the lowest: compounds 3 and 1 (each within the scatter of the next); then compound 2.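

In this assay, among these compounds, the replacement of dipropylamino by (1-methylbutyl)amino on the aromatic carbon between two ring nitrogen atoms gives a 1.3-fold lower number from compound 1 to compound 3 (0.10 log units; within the scatter), the first single-place step at this position. Within this pair, the position takes an amine with 1 hydrogen-bond donor and 1 defined stereocentre in place of one with 0 hydrogen-bond donors, with no separation of the two numbers beyond the scatter. No measurement at hand bears on why the two amines read alike.

As far as these compounds go, what remains open is whether this tolerance extends to the opposite configuration of (1-methylbutyl)amino, to a shorter chain such as ethylamino, or to a ring amine such as morpholine on the same carbon. Among the compounds shown here, compound 2 differs from compound 1 in more than one place, so its higher number in this assay cannot be assigned to its amine or to its aromatic substituent, and a compound carrying only one of those two changes would be needed to separate them.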